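The source may report more compounds than this note shows. Statements on the series, on what has been measured and on what is new or still open speak of the compounds shown alone.

Compound 1 `Cc1ccc(-n2cc(-c3ccccc3NS(=O)(=O)c3c[nH]c(=O)[nH]c3=O)nn2)cc1`: 2190 nM
Compound 3 `Cc1ccccc1-n1cc(-c2ccc(NS(=O)(=O)c3c[nH]c(=O)[nH]c3=O)cc2)nn1`: 7310 nM
Compound 2 `O=c1[nH]cc(S(=O)(=O)Nc2cccc(-c3cn(-c4ccc(F)cc4)nn3)c2)c(=O)[nH]1`: > 20000 nM

In a functional assay on OVCAR-3 cells (Homo sapiens) for antiproliferative activity, read by MTT assay, with a stated time of 24 h (a lower number here means a stronger inhibitor, a higher number a weaker inhibitor), compound 1 gives 2190 nM. Compound 3 gives 7310 nM in this assay, the higher of the two numbers, and its gap to compound 1 lies beyond the usual scatter. Compound 2 reaches only the limit of this assay at > 20000 nM, a limit and not a number (the limit of > 20000 nM in this assay, at which 1 of the 3 values shown sits). Compound 4 `O=c1[nH]cc(S(=O)(=O)Nc2ccc(-c3cn(-c4ccc(Cl)cc4)nn3)cc2)c(=O)[nH]1` has not yet been measured; it differs from compound 3 by 4-chlorophenyl in place of 2-methylphenyl on an aromatic nitrogen. Going by the values given here, no step between measured compounds covers this exchange, so the direction is open. The step from compound 3 to compound 4 is expected to be about a 1.1-fold higher number from compound 3 to compound 4 (0.04 log units; within the scatter), likely within the scatter. Compound 4 is therefore expected to give roughly 8000 nM, between 2500 nM and 25000 nM.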

Compound 4, half-maximal inhibitory concentration: 2160 nM
The estimate for compound 4 lay 3.7-fold (0.57 log units) above the measured number; the whole stated range lies above it.
By their numbers in this assay, from the lowest: compounds 4 and 1 (each within the scatter of the next); then compound 3. At a limit, above all of these: compound 2.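

Going by these compounds alone, exchanging 2-methylphenyl for 4-chlorophenyl on the aromatic nitrogen gives a 3.4-fold lower number from compound 3 to compound 4 (0.53 log units; beyond the scatter) in this assay, so the group at this position alone can shift the number, which the earlier compounds, each differing in more than one place, could not show. Nothing measured here accounts for this step.

Within the data shown here, the single exchange moves the substituent and changes its kind at once, so it remains open which of the two carries the step. On these data alone, how a 2-chlorophenyl or a 4-methoxyphenyl group would behave at this position also remains open.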